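This account rests on a few compounds, and the source may have more. Where it says the series, first, only, none or still open, it means among the compounds named here.

Compound 1 `COc1ccccc1N1CCN(CCCNc2ncccc2C(=O)N(C)C)CC1` carries a methoxy group on an aromatic carbon of the shared core, and in a functional assay for antagonist activity at Alpha-1A adrenergic receptor (Oryctolagus cuniculus) (on this read-out lower numbers stand for tighter binding and higher numbers for weaker binding), compound 1 gives 1.59 nM. Compound 2 `CN(C)C(=O)c1cccnc1NCCCN1CCN(c2ccccc2Cc2ccccc2)CC1` has a benzyl group on that carbon instead, and in this assay compound 2 gives 6.31 nM. That single exchange produced a 4.0-fold higher number from compound 1 to compound 2 (0.60 log units; beyond the scatter). Going by the values given here, of the two numbers measured so far, compound 2 holds the higher one, with compound 1 as its only neighbour.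

Compound 3 `CC(C)c1ccccc1N1CCN(CCCNc2ncccc2C(=O)N(C)C)CC1` varies the same place again: isopropyl in place of benzyl on an aromatic carbon. The group sits on an aromatic carbon of a six-membered aromatic ring of carbon only, ortho to a large group. Among the compounds with values here, the only measured step that bears on this position is the one from methoxy to benzyl, which was modest but beyond the scatter. Within the data shown here, no measured compound carries isopropyl, so no step shows its effect directly. Compound 3 is expected to move by a 1.6-fold lower number from compound 2 to compound 3 (0.20 log units; within the scatter) in this assay, a partial return toward compound 1, because a 4.0-fold higher number from compound 1 to compound 2 (0.60 log units; beyond the scatter) followed the entry of the benzyl group that now leaves. For compound 3 the estimate is therefore 4 nM, with a range from 1.3 nM to 13 nM.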

Compound 3, dissociation constant: 0.398 nM
Compound 3: the middle estimate sits 10-fold (1.00 log units) above what was measured; the whole stated range lies above it.
By their numbers in this assay, from the lowest: compound 3; then compound 1; then compound 2.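

Taking out the benzyl group does far more than undo its earlier cost: in this assay there is a 16-fold lower number from compound 2 to compound 3 (1.20 log units; beyond the scatter), a step larger than the one that came with the benzyl group. The change also goes past the starting point, with a 4.0-fold lower number from compound 1 to compound 3 (0.60 log units; beyond the scatter), so compound 3 has the lowest number of the three and its steps to both others lie beyond the scatter. Until now this aromatic carbon had shown only a rise, but these compounds show that a group there can move the number in either direction, and that isopropyl, with no ring and only carbon atoms, gives a lower number than either methoxy or benzyl. Nothing measured here gives a reason for these shifts.

The compounds shown leave open how the number would respond to other groups on this carbon, such as ethyl, a cyclopropyl ring, an amine or a carboxylic acid. They also leave open whether the order of these three compounds would hold at any other receptor.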